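This account rests on a few compounds, and the source may have more. Where it says the series, first, only, none or still open, it means among the compounds named here.

Compound 1 `O=c1[nH]/c(=N\OCCCCc2ccccc2)ccn1[C@@H]1O[C@H](COP(=O)(O)OP(=O)(O)OP(=O)(O)O)[C@@H](O)[C@H]1O` is the reference point. In a functional assay on 1321-N1 cells for agonist activity at P2Y purinoceptor 4 (Homo sapiens), read by scintillation counting and inositol phosphate accumulation (a higher number here means that more compound is needed for the effect, a lower number that less compound is needed), compound 1 gives 54 nM, the lowest number of the three measured compounds, with compound 2 `O=c1[nH]/c(=N\OCCCc2cccc(I)c2)ccn1[C@@H]1O[C@H](COP(=O)(O)OP(=O)(O)OP(=O)(O)O)[C@@H](O)[C@H]1O` nearest at 114 nM and compound 3 `O=c1[nH]/c(=N\OCCCc2ccncc2)ccn1[C@@H]1O[C@H](COP(=O)(O)OP(=O)(O)OP(=O)(O)O)[C@@H](O)[C@H]1O` furthest at 250 nM. The move to compound 4 `O=c1[nH]/c(=N\OCCCc2ccsc2)ccn1[C@@H]1O[C@H](COP(=O)(O)OP(=O)(O)OP(=O)(O)O)[C@@H](O)[C@H]1O` is described by thiophen-3-yl in place of benzyl on a saturated chain carbon, three bonds along the chain from an oxygen.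

Among the measured compounds shown here, two measured steps bear on this change, since both also exchange the benzyl group on the chain for a shorter aromatic unit. The exchange for 3-iodophenyl gave a 2.1-fold higher number from compound 1 to compound 2 (0.32 log units; beyond the scatter), and the exchange for pyridin-4-yl gave a 4.6-fold higher number from compound 1 to compound 3 (0.67 log units; beyond the scatter). Both ran in the same direction, and neither was large. A thiophen-3-yl entering at the same place is therefore expected to give a modest rise in the number, again beyond the scatter.

On that basis compound 4 is expected to read about 140 nM in this assay, within a range from 70 nM to 280 nM, corresponding to an estimated step of a 2.6-fold higher number from compound 1 to compound 4 (0.41 log units; beyond the scatter).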

Compound 4, half-maximal effective concentration: 20 nM
Compound 4: the middle estimate sits 7.0-fold (0.85 log units) above what was measured, and the stated range ends above it.
By their numbers in this assay, from the lowest: compound 4; then compound 1; then compound 2; then compound 3.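

In this assay, thiophen-3-yl in place of benzyl on the saturated chain carbon gave a 2.7-fold lower number from compound 1 to compound 4 (0.43 log units; beyond the scatter) and thereby reversed the direction of the two earlier exchanges, which had both raised the number, so leaving benzyl at this place does not by itself cost activity. The gaps to the other two groups at this place are wider, with a 5.7-fold lower number from compound 2 to compound 4 (0.76 log units; beyond the scatter) and a 13-fold lower number from compound 3 to compound 4 (1.10 log units; beyond the scatter) showing that the identity of the entering ring sets both the direction and the size of the step. Nothing measured here accounts for this difference between the rings.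

From the compounds shown here alone, it remains open whether thiophen-2-yl, furan-3-yl or an unsubstituted phenyl at the same place would read like compound 4. A longer chain carrying the thiophen-3-yl is equally unresolved.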